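Phenoxy in place of 4-fluorophenyl on the saturated ring

A few compounds are considered here, and "the series" means these few. Any claim that something is new, unique, unknown or untested is made for them only; others in the source may bear on it.

In an ADME assay on liver (Mesocricetus auratus) for metabolic stability, using microsomes (on this read-out higher numbers stand for fast clearance and lower numbers for slow clearance), compound 3 (`O=C(Nc1cc(-c2ccccn2)n[nH]1)N1CCC(c2ccc(F)cc2)CC1`) gives 272 mL.min-1.g-1, within the scatter of compound 1 (`O=C(Nc1cc(-c2ccccn2)n[nH]1)N1CCC(c2cccc(F)c2)CC1`) at 207 mL.min-1.g-1. Compound 2 (`N#Cc1ccc(OC2CCN(C(=O)Nc3cc(-c4ccccn4)n[nH]3)CC2)cc1`) gives 30.8 mL.min-1.g-1.

Compound 4 (`O=C(Nc1cc(-c2ccccn2)n[nH]1)N1CCC(Oc2ccccc2)CC1`) is next: phenoxy in place of 4-fluorophenyl on a saturated ring carbon. Among the measured compounds shown here, the steps that bear on it are an 8.8-fold higher number from compound 2 to compound 3 (0.95 log units; beyond the scatter) and a 6.7-fold lower number from compound 1 to compound 2 (0.83 log units; beyond the scatter), both beyond the scatter, with 4-cyanophenoxy carrying the lower number. For the measured compounds named here, compound 4 has phenoxy without the nitrile, and no measured pair isolates the nitrile, so only part of that size is expected. The expected change is a 2.7-fold lower number from compound 3 to compound 4 (0.43 log units; beyond the scatter), towards a lower number. Compound 4 is estimated at 100 mL.min-1.g-1, with an expected range of 40 mL.min-1.g-1 to 240 mL.min-1.g-1.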

Compound 4, intrinsic clearance in microsomes: 98.5 mL.min-1.g-1
For compound 4 the middle estimate is 1.0-fold (0.01 log units) above the measured one, within the range that was stated.
By their numbers in this assay, from the lowest: compound 2; then compound 4; then compounds 1 and 3 (each within the scatter of the next).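

In this assay, phenoxy separates from both fluorophenyl groups on the saturated ring carbon, with a 2.8-fold lower number from compound 3 to compound 4 (0.44 log units; beyond the scatter) and a 2.1-fold lower number from compound 1 to compound 4 (0.32 log units; beyond the scatter). Hydrogen in place of cyano on an aromatic carbon now isolates the nitrile, giving a 3.2-fold higher number from compound 2 to compound 4 (0.50 log units; beyond the scatter), so the low number of compound 2 comes from both the phenoxy and the nitrile. No measurement shown here explains either change.

Still open, from the compounds shown here alone, is how methoxy or chloro in place of cyano on that aromatic carbon would compare. Also open, going by these compounds, is whether an amine on the saturated ring carbon would follow phenoxy.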